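Replacing an Aryl Amide Ring with a Thiophene Ring

The source may hold more compounds than are shown below. What is called first, only, known or untested is meant among the compounds shown, and "the series" means these compounds.

Measured compounds:
- compound 1, `COc1ccc(-c2cn3cc(C4=CCN(S(=O)(=O)c5ccccc5)CC4)ccc3n2)cc1OC`: 12600 nM
- compound 2, `COc1ccc(-c2cn3cc(C4=CCN(C(=O)c5cccc(C(F)(F)F)c5)CC4)ccc3n2)cc1OC`: 4860 nM

Both were tested in a functional assay on HeLa cells (Homo sapiens) for antiproliferative activity, read by MTT assay, with a stated time of 48 h; on this read-out lower numbers stand for stronger inhibition and higher numbers for weaker inhibition. Among the compounds with values here, compound 2 holds the lowest of the two numbers, and the only neighbour is compound 1; the single measured step, a 2.6-fold lower number from compound 1 to compound 2 (0.41 log units; beyond the scatter), concerns the group on the ring nitrogen, not the ring on the carbonyl. Compound 3, `COc1ccc(-c2cn3cc(C4=CCN(C(=O)c5cccs5)CC4)ccc3n2)cc1OC`, differs from compound 2 by thiophen-2-yl in place of 3-(trifluoromethyl)phenyl on a carbonyl carbon. Within the data shown here, no measured step touches this part of the molecule, so the expectation rests on the size of that one known step and leans to caution: a change of roughly the same order, more likely toward a higher number than a lower one. Compound 3 is therefore expected to give about 7500 nM, with a range from 2500 nM to 22000 nM, which means an estimated 1.5-fold higher number from compound 2 to compound 3 (0.19 log units; within the scatter).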

Compound 3, half-maximal inhibitory concentration: 16000 nM
For compound 3 the middle estimate is 2.1-fold (0.33 log units) below the measured one, and the stated range covers the measured number.
By their numbers in this assay, from the lowest: compound 2; then compounds 1 and 3 (each within the scatter of the next).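

In this assay the group on the carbonyl carbon clearly matters: thiophen-2-yl in place of 3-(trifluoromethyl)phenyl gives a 3.3-fold higher number from compound 2 to compound 3 (0.52 log units; beyond the scatter). The other new step, a 1.3-fold higher number from compound 1 to compound 3 (0.10 log units; within the scatter), means that compound 3, with (thiophen-2-yl)carbonyl on the ring nitrogen, cannot be told apart from compound 1, with phenylsulfonyl there. The lower number of compound 2 therefore does not come with the carbonyl link alone; it depends on what the carbonyl carries as well.

The data shown include no measurement that explains this difference. On these data alone, it also remains open whether the lower number of compound 2 follows the trifluoromethyl group or the six-membered ring, a question that a plain phenyl group on the same carbonyl could help to settle.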